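The source may hold more compounds than are shown below. What is called first, only, known or untested is meant among the compounds shown, and "the series" means these compounds.

Values in a functional assay on SK-OV-3 cells (Homo sapiens) for antiproliferative activity, read by sulforhodamine B assay, with a stated time of 72 h (a higher number here means a weaker inhibitor, a lower number a stronger inhibitor), for the compounds measured so far

Compound 1 `Cc1cc(C)nc(NS(=O)(=O)c2ccc(Nc3nncc4ccccc34)cc2)n1` gives 0.08 nM
Compound 2 `C(=C/c1ccccc1)\C(=N\Nc1nncc2ccccc12)c1ccccc1` gives 0.01 nM
Compound 3 `Fc1ccc(Nc2nncc3ccccc23)cc1` gives 0.06 nM

Compound 1 and compound 3 lie level within the usual scatter of repeated measurements, while compound 2 gives a clearly lower number, beyond that scatter. Compound 1 therefore belongs to the higher pair of the three numbers.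

The next compound to be tested is compound 4 `Cc1cc(NS(=O)(=O)c2ccc(Nc3nncc4ccccc34)cc2)no1` and it keeps the core of compound 1. The change 5-methyl-1,2-oxazol-3-yl in place of 4,6-dimethylpyrimidin-2-yl on a sulfonamide nitrogen puts 5-methyl-1,2-oxazol-3-yl in place of 4,6-dimethylpyrimidin-2-yl on a sulfonamide nitrogen.

Among the measured compounds shown here, no two measured compounds differ in only one place, so the data say nothing directly about such a swap. In this assay no step beyond the scatter is expected, and the estimate stays close to compound 1 at 0.08 nM as the nearest measured relative. The expected step of a 1.1-fold lower number from compound 1 to compound 4 (0.06 log units; within the scatter) is small. Compound 4 is expected at 0.07 nM with an estimated range from 0.02 nM to 0.25 nM in this measurement.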

Compound 4, half-maximal inhibitory concentration: 6.7 nM
The estimate for compound 4 lay 96-fold (1.98 log units) below the measured number; measured number outside the range, above it.
By their numbers in this assay, from the lowest: compound 2; then compounds 3 and 1 (each within the scatter of the next); then compound 4.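

Among the compounds shown, this is the first comparison that changes only one place, and it shows that the group on the sulfonamide nitrogen strongly affects the result. In this assay, putting 5-methyl-1,2-oxazol-3-yl in place of 4,6-dimethylpyrimidin-2-yl gives an 84-fold higher number from compound 1 to compound 4 (1.92 log units; beyond the scatter) and so a much weaker inhibitor, even though the rest of the molecule stays the same. No measurement here explains this loss, and the swap alters the ring size, the hetero atoms and the number of methyl groups all at once.

Among the compounds shown here, it remains open which of these differences matters most, since no compound changes just one of them. It is also unknown how a plain phenyl ring or an unsubstituted pyridine ring would behave on this nitrogen.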